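Chloro for methyl on the phenyl of compound 2

The compounds below may be only part of what the source reports. "The series", "measured", "known", "first", "only" and "open" are said of these compounds alone.

Compound 2 `CCc1nc2c(C)cc(C)nc2n1Cc1ccc(OC(C(=O)O)c2ccccc2C)cc1` and compound 1 `CCCc1nc2c(C)ccnc2n1Cc1ccc(OC(C(=O)O)c2ccccc2)cc1` share a core and differ at several places. In an assay on Midbrain with Type-2 angiotensin II receptor (Rattus norvegicus) as the target (on this read-out higher numbers stand for weaker inhibition and lower numbers for stronger inhibition), compound 2 gives 5200 nM, and compound 1 gives 3400 nM; the two lie within the usual scatter of each other, so no order between them can be read. Compound 3 `CCc1nc2c(C)cc(C)nc2n1Cc1ccc(OC(C(=O)O)c2ccccc2Cl)cc1` carries chloro in place of methyl on an aromatic carbon. Within the data shown here, no step between two measured compounds isolates such an exchange, so no size beyond the scatter is expected in either direction. Compound 3 is estimated at 4500 nM, with a range of 1800 nM to 11000 nM, an expected step of a 1.2-fold lower number from compound 2 to compound 3 (0.06 log units; within the scatter).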

Compound 3, half-maximal inhibitory concentration: 15000 nM
Estimate against measurement, compound 3: 3.3-fold (0.52 log units) below; the whole stated range lies below it.
By their numbers in this assay, from the lowest: compounds 1 and 2 (each within the scatter of the next); then compound 3.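

In this assay, among these compounds, the exchange of 2-methylphenyl for 2-chlorophenyl gives a 2.9-fold higher number from compound 2 to compound 3 (0.46 log units; beyond the scatter), the first single-place step. This position is therefore not indifferent to the change, and here chloro gives weaker inhibition than methyl. Nothing available accounts for this step.

As far as these compounds go, whether a fluoro or methoxy group at this place would give weaker or stronger inhibition than methyl or chloro remains open. Also open, from the compounds shown here alone, is whether the same exchange gives a similar step on the core of compound 1.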